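Pyrazine in place of pyrimidine on the shared core

The source may report more compounds than this note shows. Statements on the series, on what has been measured and on what is new or still open speak of the compounds shown alone.

Compound 2 `Cc1ccc([C@H](C)NC(=O)COc2cc(C)c3c(-c4ncccn4)nn(C)c3n2)cc1` gives 4 nM in a functional assay on isolated protein for antagonist activity at Orexin/Hypocretin receptor type 1 (Homo sapiens), read by fluorescence, FLIPR and calcium flux, with a stated time of 1 h (on this read-out higher numbers stand for weaker inhibition and lower numbers for stronger inhibition), the lowest of the two numbers recorded. The nearest is compound 1 `COc1ccc(CNC(=O)COc2cc(C(F)(F)F)c3c(-c4ccccc4)nn(C)c3n2)cc1`, which in this assay gives 800 nM, a gap beyond the scatter. Compound 3 `Cc1ccc([C@H](C)NC(=O)COc2cc(C)c3c(-c4cnccn4)nn(C)c3n2)cc1` keeps the atoms of compound 2 but joins them differently: pyrazin-2-yl in place of pyrimidin-2-yl on an aromatic carbon. Within the data shown here, no step between measured compounds isolates this change, so the numbers give no direct guide to its size. Compound 3 is expected to stay potent with at most a modest loss, as a 2.5-fold higher number from compound 2 to compound 3 (0.40 log units; beyond the scatter). The estimate for compound 3 in this assay is 10 nM, within 3 nM to 40 nM.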

Compound 3, inhibition constant in the Orexin/Hypocretin receptor type 1 assay: 52 nM
Estimate against measurement, compound 3: 5.2-fold (0.72 log units) below; measured number outside the range, above it.
By their numbers in the Orexin/Hypocretin receptor type 1 assay, from the lowest: compound 2; then compound 3; then compound 1.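

Swapping pyrimidin-2-yl for pyrazin-2-yl on this aromatic carbon weakens inhibition in the Orexin/Hypocretin receptor type 1 assay, with a 13-fold higher number from compound 2 to compound 3 (1.11 log units; beyond the scatter). The two groups have the same atoms and counts and differ only in how the ring is joined, so this position responds to that arrangement alone, which the large gap between compound 1 and compound 2 could not show. The same change also comes with a solubility gain in a physicochemical assay for solubility, measured as thermodynamic solubility, at pH 6.8 (on this read-out lower numbers stand for lower solubility and higher numbers for higher solubility), where compound 2 gives 43000 nM and compound 3 gives 115000 nM: the measured solubility of compound 2, 43000 nM, and of compound 3, 115000 nM, a 2.7-fold higher number (0.43 log units; beyond the scatter)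

On these data alone, it remains open whether pyridin-2-yl or pyridazin-3-yl on this carbon would match compound 2 in the Orexin/Hypocretin receptor type 1 assay while keeping the solubility of compound 3.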